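Swapping an Aromatic Ring for Methyl Beside the Chain Oxygen

The compounds below may be only part of what the source reports. "The series", "measured", "known", "first", "only" and "open" are said of these compounds alone.

Compound 2 `OC(CCn1nc2c(Br)c(Br)c(Br)c(Br)c2n1)c1ccc(Br)cc1` carries a 4-bromophenyl on a saturated chain carbon bound to an oxygen on a saturated carbon and a saturated chain carbon. In a functional assay on CCRF-CEM cells (Homo sapiens) for antiproliferative activity, read by MTT assay, with a stated time of 24 h, tested at 25 uM (a higher number here means a weaker effect of the compound at the concentration tested, a lower number a stronger effect), compound 2 gives 109%. Going by the values given here, its only measured relative is compound 1 `OC(CCn1nc2c(Br)c(Br)c(Br)c(Br)c2n1)c1cccc(Cl)c1`, which has a 3-chlorophenyl in that place; in this assay compound 1 gives 118%. The step of a number 9 percentage points lower from compound 1 to compound 2 (within the scatter) shows that exchanging one aromatic ring for another here leaves the read-out essentially unchanged. Among the compounds with values here, compound 3 `CC(O)CCn1nc2c(Br)c(Br)c(Br)c(Br)c2n1` has not been measured. methyl in place of 4-bromophenyl on a saturated chain carbon bound to an oxygen on a saturated carbon and a saturated chain carbon No measured step replaces an aromatic ring with a small alkyl group, so the single known step is only a loose guide; it suggests that this position tolerates change without a shift in this assay beyond the scatter. Compound 3 is therefore expected to give about 110%, within 90% to 130%, an estimated step of a number 1 percentage points higher from compound 2 to compound 3 (within the scatter).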

Compound 3, a percentage reported as activity, at one concentration (the size of the read-out at that concentration, not a potency): 113%
Compound 3: the middle estimate sits 3 percentage points below what was measured, and the stated range covers the measured number.
By their numbers in this assay, from the lowest: compounds 2, 3 and 1 (each within the scatter of the next).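

In this assay the aromatic ring at this place can go entirely without a shift beyond the scatter: methyl in place of 4-bromophenyl gives a number 4 percentage points higher from compound 2 to compound 3 (within the scatter) and methyl in place of 3-chlorophenyl gives a number 5 percentage points lower from compound 1 to compound 3 (within the scatter) and so neither step stands out. Going by these compounds alone, the earlier compounds showed only one aromatic ring exchanged for another, whereas here 7 heavy atoms leave, 1 enters, and the three compounds still cannot be told apart in this read-out. Nothing measured here explains this lack of response.

As far as these compounds go, whether an amine, a carboxylic acid or a longer chain on this saturated chain carbon would move the read-out remains open. So does the part played by the oxygen on the saturated carbon, which all three compounds keep.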